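Swapping the carbamoyl arm for a fluorobenzyl ester

The source may report more compounds than this note shows. Statements on the series, on what has been measured and on what is new or still open speak of the compounds shown alone.

Among the compounds with values here, compound 2 `CCn1c(C(=O)NCC(OC)OC)ccc1C(CC)(CC)c1ccc(OCC(O)C(C)(C)C)c(C)c1` sits at the high end of the two numbers so far: in a functional assay on HepG2 cells (Homo sapiens), read by MTT assay, with a stated time of 48 h (a higher number here means a weaker inhibitor, a lower number a stronger inhibitor), compound 2 gives 23200 nM, whereas compound 1 `CCN(CC)CCNC(=O)c1ccc(C(CC)(CC)c2ccc(OCC(=O)C(C)(C)C)c(C)c2)n1CC` gives 620 nM, a gap well beyond the usual scatter. Compound 3 `CCn1c(C(=O)OCc2ccc(F)cc2)ccc1C(CC)(CC)c1ccc(OCC(O)C(C)(C)C)c(C)c1` differs from compound 2 in one place: (4-fluorobenzyl)oxy in place of (2,2-dimethoxyethyl)amino on a carbonyl carbon. Within the data shown here, no measured pair shows this exact change, so its size is uncertain; a modest move toward a lower number seems plausible but not assured. The expected step of a 1.9-fold lower number from compound 2 to compound 3 (0.29 log units; within the scatter) reflects that guess. Compound 3 is estimated at 12000 nM, within 3000 nM to 50000 nM.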

Compound 3, half-maximal inhibitory concentration: > 50000 nM
Compound 3 was reported as a limit; the forecaster's own chance of this, stated with the estimate: 10%; at least 4.1-fold (0.61 log units) between middle value and limit.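

On the carbonyl carbon, (4-fluorobenzyl)oxy in place of (2,2-dimethoxyethyl)amino gives an at least 2.1-fold higher number from compound 2 to compound 3 (0.33 log units; beyond the scatter) in this assay. Within the data shown here, this is the first single-place comparison here, and it shows that changing this one group alone can move the number, in this case toward a weaker inhibitor. Compound 3 is reported only as a limit, so the step gives a minimum size and not an exact one: the limit of > 50000 nM in this assay, at which 1 of the 3 values shown sits.

On these data alone, it remains open whether a carboxylic acid, a methyl amide or an unsubstituted benzyl ester on this carbonyl carbon would read closer to compound 2 or to compound 3.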